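This account rests on a few compounds, and the source may have more. Where it says the series, first, only, none or still open, it means among the compounds named here.

Measured compounds:
- compound 1, `CC(=O)NCC#CCn1cncc1C` — in a functional assay on the whole organism for antagonist activity, with Mus musculus as the target (a lower number here means that less compound is needed, a higher number that more compound is needed for the effect), compound 1 gives 66 mg/kg
- compound 3, `COC(=O)NCC#CCn1cncc1C` — in this assay compound 3 gives 80 mg/kg
- compound 2, `CC(=O)N(C)CC#CCN1CCCC1` — in this assay compound 2 reaches only a limit, > 10 mg/kg

The pair compound 1 and compound 3 share a core and differ in one place, (methoxy in place of methyl on a carbonyl carbon). The step this change made is a 1.2-fold higher number from compound 1 to compound 3 (0.08 log units; within the scatter), so the two values sit within the usual scatter of each other and no order between them is read.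

Compound 2 carries a different core; the difference between the core of compound 2 and the core of compound 1 is not broken down here. Compound 2 gives only a limit in this assay, (the limit of > 10 mg/kg in this assay, at which 1 of the 3 values shown sits).

Compound 4, `COC(=O)N(C)CC#CCN1CCCC1`, is not yet measured. It differs from compound 2 by methoxy in place of methyl on a carbonyl carbon, the same change that takes compound 1 to compound 3, on the same kind of place. On the evidence of compound 1 and compound 3, this change left the dose essentially unmoved, a 1.2-fold higher number from compound 1 to compound 3 (0.08 log units; within the scatter). The same is therefore expected from compound 2 to compound 4, a step that the limit leaves unreadable from compound 2 to compound 4. Since the starting point for compound 2 is a limit rather than a number, the expectation for compound 4 is accordingly broad, and it is likely that compound 4 too will return only a limit. The estimated dose for compound 4 in this assay is 40 mg/kg, expected to fall between 12 mg/kg and 150 mg/kg.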

Compound 4, dose for half-maximal effect: > 10 mg/kg
Compound 4: no number, only a limit; the forecaster's own chance of this, stated with the estimate: 60%; the middle value is on the limit's open side.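

In this assay, compound 2 and compound 4 each return only a limit, so no step can be read for methoxy in place of methyl on a carbonyl carbon between them: the limit of > 10 mg/kg in this assay, at which 2 of the 4 values shown sit.

The compounds shown leave open where the doses of compound 2 and compound 4 actually lie, and whether this change acts on the core of compound 2 as it does on the core of compound 1.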